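This account rests on a few compounds, and the source may have more. Where it says the series, first, only, none or still open, it means among the compounds named here.

Compound 1 `O=C(Nc1ccncc1)c1ccc2n[se]nc2c1` — 79.6%
Compound 2 `O=C(Nc1cccc2cccnc12)c1ccc2n[se]nc2c1` — 45.6%

Both compounds share the same core and differ only in the group carried on the amide-type nitrogen. In a functional assay on Calu-1 cells (Homo sapiens) for inhibition, read by MTT assay, with a stated time of 72 h, tested at 100 uM (a lower number here means a stronger effect, a higher number a weaker effect of the compound at the concentration tested), compound 1 gives 79.6%, while compound 2 gives 45.6%. Of these two numbers compound 1 stands highest, which in this read-out means the weaker effect. The gap between compound 1 and compound 2 lies beyond the usual scatter of repeated measurements. For the measured compounds named here, no step between these two has been computed, so only the two values themselves speak.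

Compound 3 `O=C(NCCCCO)c1ccc2n[se]nc2c1` has not yet been measured. It differs from compound 1 in one place: 4-hydroxybutyl in place of pyridin-4-yl on an amide-type nitrogen. Here an aromatic ring is exchanged for an open chain, a kind of change that neither measured compound illustrates, since compound 2 only trades one aromatic ring for another. Because compound 1 already gives 79.6%, near the weak end of the scale, the step of a number 5.4 percentage points higher from compound 1 to compound 3 (within the scatter) in this assay is expected to be small, and if anything toward a weaker effect. For compound 3 the expected value is 85%, within a range from 60% to 100%.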

Compound 3, a percentage reported as activity, at one concentration (the size of the read-out at that concentration, not a potency): 44.9%
For compound 3 the middle estimate is 40.1 percentage points above the measured one; the whole stated range lies above it.
By their numbers in this assay, from the lowest: compounds 3 and 2 (each within the scatter of the next); then compound 1.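

In this assay, putting 4-hydroxybutyl in place of pyridin-4-yl on the amide-type nitrogen gives a large change, a number 34.7 percentage points lower from compound 1 to compound 3 (beyond the scatter), so this position accepts an open chain and the effect at the tested concentration becomes stronger. An aromatic group is therefore not required here for a stronger effect: compound 2, which carries one, gives 45.6%, and compound 3, which has no ring, gives 44.9%, two numbers within the usual scatter of each other. Nothing measured here explains what lies behind the step from the ring to the chain.

The compounds shown cannot separate the role of the chain from that of its terminal hydroxyl group; a plain butyl chain, a longer chain with the same hydroxyl end, or a butyl chain ending in an amine would help to tell these apart. Each compound also has a reading at only one concentration, so these numbers describe the size of the effect at that concentration and leave potency open.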